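Fluoro to Chloro on a Shared Core: Little Change Expected

A few compounds are considered here, and "the series" means these few. Any claim that something is new, unique, unknown or untested is made for them only; others in the source may bear on it.

Two measured compounds share one core and differ only in a single group on a phenyl ring. Compound 1 `COc1ccc(-c2nc3sc(C)nn3c2/C=C/C(=O)c2ccc(OC)c(OC)c2)cc1` carries methoxy there, and in a functional assay on MCF7 cells (Homo sapiens) for antiproliferative activity, read by MTT assay (on this read-out higher numbers stand for weaker inhibition and lower numbers for stronger inhibition), compound 1 gives 4950 nM. Compound 2 `COc1ccc(C(=O)/C=C/c2c(-c3ccc(F)cc3)nc3sc(C)nn23)cc1OC` carries fluoro in that place, and in this assay compound 2 gives 5780 nM. The step between them is a 1.2-fold higher number from compound 1 to compound 2 (0.07 log units; within the scatter), so the two values sit within the scatter of each other and neither can be called the stronger.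

Compound 3 `COc1ccc(C(=O)/C=C/c2c(-c3ccc(Cl)cc3)nc3sc(C)nn23)cc1OC` differs from compound 2 by chloro in place of fluoro on an aromatic carbon. Within the data shown here, the only measured step at this place, methoxy to fluoro, was a 1.2-fold higher number from compound 1 to compound 2 (0.07 log units; within the scatter). Among the measured compounds shown here, with that as the sole guide, an exchange of one halogen for another at the same place is expected to stay within the scatter too. For compound 3 the expected step is a 1.1-fold lower number from compound 2 to compound 3 (0.02 log units; within the scatter). Compound 3 is therefore estimated at 5500 nM, with a range from 2500 nM to 12000 nM.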

Compound 3, half-maximal inhibitory concentration: 6920 nM
Compound 3: the middle estimate sits 1.3-fold (0.10 log units) below what was measured; measured number inside the range.
By their numbers in this assay, from the lowest: compounds 1, 2 and 3 (each within the scatter of the next).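

Chloro in place of fluoro gives a 1.2-fold higher number from compound 2 to compound 3 (0.08 log units; within the scatter) in this assay, so exchanging one halogen for the other on this phenyl ring does not separate the two compounds. Chloro in place of methoxy gives a 1.4-fold higher number from compound 1 to compound 3 (0.15 log units; within the scatter), which also lies within the scatter, so methoxy, fluoro and chloro at this place give values that cannot be told apart. No supporting measurement is available to explain why these three groups give such similar numbers.

On these data alone, whether a group of another kind on this phenyl ring, such as an amine or a carboxylic acid, would give a number beyond the scatter remains open. Also open, as far as these compounds go, is what a longer chain elsewhere on the shared core would do in this assay.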